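This account rests on a few compounds, and the source may have more. Where it says the series, first, only, none or still open, it means among the compounds named here.

Three compounds share one core and differ only in the group on a saturated ring carbon of the three-membered ring. In a functional assay for agonist activity at G protein-coupled receptor 88 (Homo sapiens), read by HTRF and cAMP accumulation (a lower number here means that less compound is needed, a higher number that more compound is needed for the effect), compound 1 `CC[C@H](C)[C@H](N)CN(C(=O)[C@@H]1C[C@H]1c1ccc(F)cc1)c1ccc(-c2ccccc2)cc1` gives 600 nM, compound 2 `CC[C@H](C)[C@H](N)CN(C(=O)[C@@H]1C[C@H]1c1cc(F)cc(F)c1)c1ccc(-c2ccccc2)cc1` gives 960 nM, and compound 3 `CC[C@H](C)[C@H](N)CN(C(=O)[C@@H]1C[C@H]1c1ccncc1)c1ccc(-c2ccccc2)cc1` gives 1500 nM, the highest of the three numbers. Compound 4 `CC[C@H](C)[C@H](N)CN(C(=O)[C@@H]1C[C@H]1c1nccs1)c1ccc(-c2ccccc2)cc1` carries the change (1,3-thiazol-2-yl in place of pyridin-4-yl on a saturated ring carbon). The measured steps that bear on this position are a 2.5-fold higher number from compound 1 to compound 3 (0.40 log units; beyond the scatter) and a 1.6-fold higher number from compound 2 to compound 3 (0.19 log units; within the scatter), both small. Because the exchanges at this position gave only a 2.5-fold higher number from compound 1 to compound 3 (0.40 log units; beyond the scatter) and a 1.6-fold higher number from compound 2 to compound 3 (0.19 log units; within the scatter), compound 4 is expected to show no change at the digits printed from compound 3 to compound 4 (within the scatter), which amounts to no step beyond the scatter. For compound 4 the estimated value in this assay is 1500 nM, with a range from 500 nM to 4500 nM.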

Compound 4, half-maximal effective concentration: 210 nM
Beside the measured number, compound 4's estimate is 7.1-fold (0.85 log units) above it; measured number below the stated range.
By their numbers in this assay, from the lowest: compound 4; then compounds 1, 2 and 3 (each within the scatter of the next, the first and the last beyond it).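

In this assay this position proves more responsive than the earlier exchanges suggested: the five-membered 1,3-thiazol-2-yl ring gives a 7.1-fold lower number from compound 3 to compound 4 (0.85 log units; beyond the scatter), along with a 4.6-fold lower number from compound 2 to compound 4 (0.66 log units; beyond the scatter) and a 2.9-fold lower number from compound 1 to compound 4 (0.46 log units; beyond the scatter). Compound 4 therefore has the lowest number of the four, beyond the scatter of each of the others. Nothing available here explains this change. The compounds shown leave open whether the low number is particular to 1,3-thiazol-2-yl or also extends to an oxazol-2-yl or imidazol-2-yl group on the same ring carbon.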